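Aminooxadiazole for methylimidazole on the cyclopropane series

A few compounds are considered here, and "the series" means these few. Any claim that something is new, unique, unknown or untested is made for them only; others in the source may bear on it.

Among the measured compounds shown here, compound 2 `Cc1[nH]cnc1[C@@H]1[C@@H](c2cccc3c2CCO3)C1(C)C` gives the higher of the two numbers so far: in a functional assay on AP1 cells for inhibition of sodium/hydrogen exchanger 1 (Homo sapiens) (on this read-out lower numbers stand for stronger inhibition and higher numbers for weaker inhibition), compound 2 gives 11000 nM, while compound 1 `CC1(C)[C@H](c2cc(Cl)cc(Cl)c2)[C@H]1c1c[nH]c(N)n1` gives 180 nM. Compound 3 `CC1(C)[C@H](c2nc(N)no2)[C@H]1c1cccc2c1CCO2` changes a single place on the core of compound 2: 3-amino-1,2,4-oxadiazol-5-yl in place of 5-methyl-1H-imidazol-4-yl on a saturated ring carbon. For the measured compounds named here, no measured pair covers this change alone, so the step is uncertain; a drift toward weaker inhibition, or none beyond the scatter, is expected, as a 1.4-fold higher number from compound 2 to compound 3 (0.13 log units; within the scatter). For compound 3 in this assay the expected value is 15000 nM, with a range from 3000 nM to 60000 nM.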

Compound 3, half-maximal inhibitory concentration: 30000 nM
The estimate for compound 3 lay 2.0-fold (0.30 log units) below the measured number; the measured number falls inside the stated range.
By their numbers in this assay, from the lowest: compound 1; then compound 2; then compound 3.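

In this assay 3-amino-1,2,4-oxadiazol-5-yl in place of 5-methyl-1H-imidazol-4-yl on a saturated ring carbon gives a 2.7-fold higher number from compound 2 to compound 3 (0.44 log units; beyond the scatter) and so shows that this position distinguishes between two five-membered aromatic rings of equal heavy-atom count. The added hydrogen-bond acceptors, with the donor count unchanged, bring no gain in inhibition. Nothing measured here accounts for this step.

Compound 1 differs from compound 2 and compound 3 in more than one place, so the part played by its amino-imidazole remains unassigned. Open, as far as these compounds go, is how an unsubstituted imidazole, a 2-aminoimidazole or a carboxamide would read on the core of compound 2.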